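Replacing the Amino Acid Arm with a Hydroxypyrrolidine

The source may report more compounds than this note shows. Statements on the series, on what has been measured and on what is new or still open speak of the compounds shown alone.

A set of compounds sharing the core of compound 1 `COc1ccc(/C=C\c2cc(OC)c(OC)c(OC)c2)cc1OCc1ccc(CN2CCCC[C@@H]2C(=O)O)cc1` was tested in a functional assay on HepG2 cells (Homo sapiens) for antiproliferative activity, read by CCK-8 assay, with a stated time of 48 h; a lower number here means a stronger inhibitor, a higher number a weaker inhibitor. In this assay compound 1 gives > 10000 nM, which is a limit of the assay rather than a number. Compound 2 `COc1ccc(/C=C\c2cc(OC)c(OC)c(OC)c2)cc1OCc1ccc(CN[C@H](C(=O)O)[C@H](C)O)cc1` likewise gives > 10000 nM in this assay, again only a limit. The step that the two limits leave unreadable from compound 1 to compound 2 therefore cannot be read, since both values sit at the limit of > 10000 nM in this assay, at which 2 of the 3 values shown sit. Among the measured compounds shown here, compound 3 `COc1ccc(/C=C\c2cc(OC)c(OC)c(OC)c2)cc1OCc1ccc(CN2CCCCC2C(=O)NCCNC(=O)OC(C)(C)C)cc1`, which carries no acid, gives 1100 nM in this assay, the only measured number among the three.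

Compound 2 thus stands at the limit, and its activity is known only to be weak. Compound 4 `COc1ccc(/C=C\c2cc(OC)c(OC)c(OC)c2)cc1OCc1ccc(CN2CC[C@@H](O)C2)cc1` differs from compound 2 by 3-hydroxypyrrolidin-1-yl in place of (1-carboxy-2-hydroxypropyl)amino on a saturated chain carbon bound to an aromatic carbon. For the measured compounds named here, no measured step covers this change: the one step available, a step that the two limits leave unreadable from compound 1 to compound 2, is unreadable, and compound 2 and compound 3 differ in more than one place, so their pair yields no step. Going by the values given here, what remains is that compound 3, the one compound without an acid, returns a number rather than a limit. For compound 4 a step beyond the scatter towards stronger inhibition is therefore expected, an at least 5.0-fold lower number from compound 2 to compound 4 (0.69 log units; beyond the scatter), though with wide uncertainty. Compound 4 is estimated at 2000 nM, within the range 300 nM to 10000 nM.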

Compound 4, half-maximal inhibitory concentration: 6200 nM
Compound 4: the middle estimate sits 3.1-fold (0.49 log units) below what was measured; the range from low to high includes it.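

In this assay, putting 3-hydroxypyrrolidin-1-yl on the saturated chain carbon bound to an aromatic carbon gives an at least 1.6-fold lower number from compound 2 to compound 4 (0.20 log units; that floor lies within the scatter) and likewise an at least 1.6-fold lower number from compound 1 to compound 4 (0.20 log units; that floor lies within the scatter). Among the compounds shown here, these are the first readable single changes at this position, and each replaces a carboxyl-bearing arm with a smaller group that carries no carboxylic acid and returns a number rather than a limit. Both steps are only floors, so the true size of the change has no upper bound and the printed floors do not establish a step beyond the scatter, because the starting points are limits and not numbers: the limit of > 10000 nM in this assay, at which 2 of the 4 values shown sit.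

The compounds shown do not separate the contribution of the ring from that of its hydroxyl, which a plain pyrrolidine or a simple open-chain tertiary amine at the same place would address. They also leave open whether the other stereoisomer of the 3-hydroxypyrrolidin-1-yl group, or an ester or amide in place of the carboxylic acid on the arm of compound 2, would read differently.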